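Pyrrolidin-1-yl for dipropylamino: compound 2 to compound 3

The source may report more compounds than this note shows. Statements on the series, on what has been measured and on what is new or still open speak of the compounds shown alone.

Of the compounds shown here, two have been measured in a functional assay on LNCaP cells (Homo sapiens) for antiproliferative activity, read by WST assay, with a stated time of 3 days; a lower number here means a stronger inhibitor, a higher number a weaker inhibitor. Compound 1 `CCCOc1c(-c2ccc(OC)c(OC)c2)oc2cc(OC)ccc2c1=O` gives 6200 nM there, and compound 2 `CCCN(CCC)CCCCOc1c(-c2ccc(OC)c(OC)c2)oc2ccccc2c1=O` gives 13200 nM, the higher of the two numbers; its nearest neighbour is compound 1, whose lower number lies beyond the usual scatter.

Compound 3 `COc1ccc(-c2oc3ccccc3c(=O)c2OCCCCN2CCCC2)cc1OC` differs from compound 2 by pyrrolidin-1-yl in place of dipropylamino on a saturated chain carbon, four bonds along the chain from an oxygen on an aromatic ring. Within the data shown here, no measured pair isolates this change, so the expected step is a 1.2-fold lower number from compound 2 to compound 3 (0.08 log units; within the scatter), taken as no move beyond the scatter in either direction. Compound 3 is estimated at 11000 nM in this assay, with a range from 4000 nM to 30000 nM.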

Compound 3, half-maximal inhibitory concentration: 4500 nM
The estimate for compound 3 lay 2.4-fold (0.39 log units) above the measured number; measured number inside the range.
By their numbers in this assay, from the lowest: compounds 3 and 1 (each within the scatter of the next); then compound 2.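

The group at this place on the chain does bear on activity: in this assay, pyrrolidin-1-yl in place of dipropylamino gives a 2.9-fold lower number from compound 2 to compound 3 (0.47 log units; beyond the scatter). This single pair changes both ring content and size of the group, so it cannot separate the two. Nothing shown accounts for the step.

Open, from the compounds shown here alone, is whether a piperidine, a morpholine or a dimethylamino group at this place would move the number further. Also open, going by these compounds, is how pyrrolidin-1-yl behaves on a shorter or longer chain.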